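This account rests on a few compounds, and the source may have more. Where it says the series, first, only, none or still open, it means among the compounds named here.

Measured in a functional assay on HL-60 cells (Homo sapiens) for antiproliferative activity; on this read-out higher numbers stand for weaker inhibition of growth and lower numbers for stronger inhibition of growth:
Compound 1 `CCCCCCCCC(O)CCCCCC/C=C1\CC(CO)(COC(=O)C(C)(C)C)OC1=O`: > 10 ug/mL, a limit of the assay.
Compound 2 `CCCCCOCCCCCCC/C=C1\CC(CO)(COC(=O)C(C)(C)C)OC1=O`: 2.96 ug/mL.

Among the compounds with values here, compound 2 holds the only true number so far, so it is the sole anchor for what follows. The next compound to be read is compound 3 `CC(=O)OCCCCCCCCCCCCCCC/C=C1\CC(CO)(COC(=O)C(C)(C)C)OC1=O`, and the change is 8-acetoxyoctyl in place of pentyloxy on a saturated chain carbon, seven bonds along the chain from a double-bonded chain carbon.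

Within the data shown here, only one measured step is available: an at least 3.3-fold lower number from compound 1 to compound 2 (0.52 log units; beyond the scatter). That step exchanges a different pair of groups on the chain, 1-hydroxynonyl for (pentyloxy)methyl, so it bears only loosely on the present change. For compound 1, its size is also only a bound, resting on (the limit of > 10 ug/mL in this assay, at which 1 of the 2 values shown sits). Neither the pentyloxy group nor the 8-acetoxyoctyl group appears in any other measured pair.

With so little to go on, no step beyond the scatter is expected in this assay, though a slightly higher number is the more likely direction. The expected step is a 1.5-fold higher number from compound 2 to compound 3 (0.18 log units; within the scatter). The estimated value for compound 3 is 4.5 ug/mL, with an expected range of 1.5 ug/mL to 14 ug/mL.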

Compound 3, concentration for 50% growth inhibition: > 10 ug/mL
Compound 3 was reported as a limit (the forecaster's own chance of this, stated with the estimate: 30%); at least 2.2-fold (0.34 log units) between middle value and limit.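

In this assay, 8-acetoxyoctyl in place of pentyloxy on a saturated chain carbon, seven bonds along the chain from a double-bonded chain carbon, gives an at least 3.3-fold higher number from compound 2 to compound 3 (0.52 log units; beyond the scatter), the first change read at this place on the chain and one that moves beyond the scatter. Going by these compounds, compound 3 gives > 10 ug/mL, a limit of the assay, so this step is a bound and its true size remains unknown. Compound 2 now has a single measured value, with a change on either side of its ether chain, in compound 1 and in compound 3, ending at the same limit, which is the reason no graded trend can be drawn from these compounds: the limit of > 10 ug/mL in this assay, at which 2 of the 3 values shown sit.

The compounds shown leave open whether the step in compound 3 follows from the size of the entering chain or from its terminal acetoxy group, a question that a plain octyl chain or an 8-hydroxyoctyl group at the same place would help to separate. Also open, on these data alone, is whether a shorter chain ending in an acetoxy group, or one ending in a carboxylic acid, would give a true number in this assay rather than a limit.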